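The source may hold more compounds than are shown below. What is called first, only, known or untested is meant among the compounds shown, and "the series" means these compounds.

Working notes on the cytotoxicity of a small set of nitro-heteroaryl sulfonamide amides in an ADME assay on IMR-90 cells (Homo sapiens) for cytotoxicity, read by CellTiter-Blue, with a stated time of 46 h; a higher number here means that more compound is needed for the effect, a lower number that less compound is needed. Compound 1 is `CC1(C)CCN(S(=O)(=O)c2ccc(NC(=O)c3ccc([N+](=O)[O-])o3)cc2)CC1`. In this assay compound 1 reaches only a limit of the assay, > 25000 nM. Compound 3 is `CC1(C)CCN(S(=O)(=O)c2ccc(NC(=O)c3ccc([N+](=O)[O-])s3)cc2)CC1`; it differs from compound 1 by 5-nitrothiophen-2-yl in place of 5-nitrofuran-2-yl on a carbonyl carbon. In this assay compound 3 likewise stops at a limit, > 25000 nM. The step that the two limits leave unreadable from compound 1 to compound 3 therefore cannot be sized, since both ends sit at the limit of > 25000 nM in this assay, at which 3 of the 3 values shown sit. Compound 2 is `O=C(Nc1ccc(S(=O)(=O)N2CCC3(CCCCC3)CC2)cc1)c1ccc([N+](=O)[O-])o1`; how its core differs from the core of compound 1 is not broken down here. In this assay compound 2 also gives only a limit, > 25000 nM. Compound 4, not yet measured, is `O=C(Nc1ccc(S(=O)(=O)N2CCC3(CCCCC3)CC2)cc1)c1ccc([N+](=O)[O-])s1`; it differs from compound 2 by 5-nitrothiophen-2-yl in place of 5-nitrofuran-2-yl on a carbonyl carbon, the same kind of change as that made from compound 1 to compound 3, described at a place given in the same words. The step from compound 2 to compound 4 is expected to be small, a step that the limit leaves unreadable from compound 2 to compound 4, an expectation that rests on the unreadable but limit-bound step that the two limits leave unreadable from compound 1 to compound 3. Compound 4 is accordingly estimated to come out near 40000 nM, somewhere from 15000 nM to 150000 nM, and most probably as a limit rather than a number, in line with the limit of > 25000 nM in this assay, at which 3 of the 3 values shown sit.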

Compound 4, half-maximal effective concentration: > 25000 nM
Compound 4: a limit, no number; the forecaster's own chance of this, stated with the estimate: 85%; the middle value does not contradict the limit.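

No step can be read from compound 2 to compound 4, since both stop at a limit of the assay and not at a number: the limit of > 25000 nM in this assay, at which 4 of the 4 values shown sit. The compounds shown leave open how far any of them lies from that limit, and whether 5-nitrothiophen-2-yl in place of 5-nitrofuran-2-yl on a carbonyl carbon changes the read-out at all in this assay.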